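The source may hold more compounds than are shown below. What is called first, only, known or untested is meant among the compounds shown, and "the series" means these compounds.

Within the data shown here, in an ADME assay on HEK-293T cells (Homo sapiens) for cytotoxicity, read by CCK-8 assay, with a stated time of 48 h (on this read-out lower numbers stand for higher toxicity in this test and higher numbers for lower toxicity in this test), compound 2 `O=C(CNc1nc(N2CCCC2)nc2ccccc12)Nc1ccc2ccccc2c1` gives 59900 nM, the only actual number among the three compounds measured so far. Compound 1 `CCN(CC)c1nc(SCC(=O)Nc2ccccc2)c2ccccc2n1` reports only a limit, > 100000 nM. Compound 3 `O=C(CSc1nc(N2CCCC2)nc2ccccc12)NCc1ccc2ccccc2c1` likewise reports only a limit, > 100000 nM. Compound 4 `O=C(CNc1nc(N2CCCC2)nc2ccccc12)Nc1ccccc1` differs from compound 2 at one place: phenyl in place of naphthalen-2-yl on an amide-type nitrogen, with phenyl in place of naphthalen-2-yl on an amide-type nitrogen. Among the measured compounds shown here, no measured pair isolates this change in this assay. For the measured compounds named here, the only guide is compound 1, which also has phenyl on an amide-type nitrogen and shows the limit > 100000 nM. The step of a 1.5-fold higher number from compound 2 to compound 4 (0.18 log units; within the scatter) is expected to point toward lower toxicity in this test, without clearly leaving the usual scatter. For compound 4 the estimate is 90000 nM, with an expected range of 45000 nM to 160000 nM.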

Compound 4, half-maximal cytotoxic concentration: 23300 nM
Beside the measured number, compound 4's estimate is 3.9-fold (0.59 log units) above it; the measured number lies below the stated range.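

In this assay, among these compounds, phenyl in place of naphthalen-2-yl on an amide-type nitrogen gives a 2.6-fold lower number from compound 2 to compound 4 (0.41 log units; beyond the scatter), the first step that can be read at this position. The position is therefore not silent: the smaller group, with one ring instead of two, goes with higher toxicity in this test, not lower. From the compounds shown here alone, this rests on a single pair, and the remaining values offer no second reading: the limit of > 100000 nM in this assay, at which 2 of the 4 values shown sit. Whether an amine or a carboxylic acid on the phenyl, or a longer chain on that nitrogen, would move the number remains open.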